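Acetamido for Hydroxy: Predicting Lipophilicity of a Thiocarbamate

The source may report more compounds than this note shows. Statements on the series, on what has been measured and on what is new or still open speak of the compounds shown alone.

Measured compounds:
- compound 1, `CC(=O)Nc1ccc(OC(=S)Nc2ccc(Nc3ccc(C(F)(F)F)cc3)cc2)cc1`: 5.32
- compound 2, `O=[N+]([O-])c1ccc(Sc2ccc(NC(=S)Oc3ccc(O)cc3)cc2)cc1`: 5.25
- compound 3, `Oc1ccc(OC(=S)Nc2ccc(Nc3ccc(C(F)(F)F)cc3)cc2)cc1`: 6.04

Three thiocarbamates have been measured in a physicochemical assay for lipophilicity; on this read-out lower numbers stand for lower lipophilicity and higher numbers for higher lipophilicity. Compound 3 gives 6.04, and compound 1 gives 5.32. The two differ in one place, (acetamido in place of hydroxy on an aromatic carbon), and this step is a number 0.72 log units lower from compound 3 to compound 1 (beyond the scatter). Compound 2 gives 5.25; it and compound 1 lie within the scatter of each other, so no order between them is claimed. The difference between the core of compound 2 and the core of compound 3 is not broken down here.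

Compound 4, `CC(=O)Nc1ccc(OC(=S)Nc2ccc(Sc3ccc([N+](=O)[O-])cc3)cc2)cc1`, has not yet been measured in this assay. It stands to compound 2 as compound 1 stands to compound 3: acetamido in place of hydroxy on an aromatic carbon. The place lines of the two changes read the same word for word, so this is the same change, seen a second time. Resting on the step of a number 0.72 log units lower from compound 3 to compound 1 (beyond the scatter), the step from compound 2 to compound 4 is expected to be of similar size, a number 0.70 log units lower from compound 2 to compound 4 (beyond the scatter). Compound 4 is therefore estimated at 4.55, with a likely range from 4.1 to 5.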

Compound 4, partition coefficient: 5.06
Compound 4: middle estimate off by 0.51 log units, on the low side, outside the stated range (above it).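

In this assay, acetamido in place of hydroxy on an aromatic carbon gives a number 0.19 log units lower from compound 2 to compound 4 (within the scatter), while the same change on the other core gives a number 0.72 log units lower from compound 3 to compound 1 (beyond the scatter). With one pair on each core, this shows that a step beyond the scatter on the core of compound 3 was not repeated beyond the scatter on the core of compound 2, so its size cannot simply be carried from one core to the other in this series, but it does not show which step is the more typical or how other cores would behave. Nothing available here bears on why the two steps differ.

The compounds shown leave open how an amine or a carboxylic acid in place of the hydroxy group would read on each of the two cores. They also leave open whether a longer chain in place of acetamido would give steps that agree between the cores.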